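From 2,6-dichlorophenyl to 3,4-dichlorophenyl: working notes

The compounds below may be only part of what the source reports. "The series", "measured", "known", "first", "only" and "open" are said of these compounds alone.

Values in a functional assay on cells (Tumor Cell line, Homo sapiens) for cytotoxicity; on this read-out lower numbers stand for stronger inhibition and higher numbers for weaker inhibition:
- compound 1 `CN(C)Cc1cc(C(=O)/C=C/c2ccccc2)cc(CN(C)C)c1O`: 21900 nM
- compound 2 `CN(C)Cc1cc(C(=O)/C=C/c2c(Cl)cccc2Cl)cc(CN(C)C)c1O`: 5880 nM

Of the two measured compounds, compound 2 has the lower number, standing at 5880 nM in this assay. The next entry, compound 3 `CN(C)Cc1cc(C(=O)/C=C/c2ccc(Cl)c(Cl)c2)cc(CN(C)C)c1O`, is not yet measured. Its change from compound 2 is 3,4-dichlorophenyl in place of 2,6-dichlorophenyl on a double-bonded chain carbon bound to a double-bonded chain carbon, with the same atoms joined differently. Among the measured compounds shown here, one measured step bears on this: a 3.7-fold lower number from compound 1 to compound 2 (0.57 log units; beyond the scatter), which came with 2,6-dichlorophenyl in place of phenyl. For the measured compounds named here, that step shows a modest shift on changing this group, but no measured pair compares chlorine placements, so no direction can be drawn from the data. An expected 1.2-fold higher number from compound 2 to compound 3 (0.08 log units; within the scatter) is therefore a small one, with no step beyond the scatter anticipated. For compound 3 the estimated value is 7000 nM, with an expected range from 2500 nM to 18000 nM.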

Compound 3, half-maximal inhibitory concentration: 2350 nM
The estimate for compound 3 lay 3.0-fold (0.47 log units) above the measured number; measured number outside the range, below it.
By their numbers in this assay, from the lowest: compound 3; then compound 2; then compound 1.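

In this assay, the placement of the chlorines on this group matters by itself: with the same atoms joined differently, 3,4-dichlorophenyl in place of 2,6-dichlorophenyl gives a 2.5-fold lower number from compound 2 to compound 3 (0.40 log units; beyond the scatter). Against plain phenyl, the 3,4-dichlorophenyl group gives a 9.3-fold lower number from compound 1 to compound 3 (0.97 log units; beyond the scatter), so both dichlorophenyl groups have lower numbers than phenyl, and compound 3 has the lowest number of the three. No measured evidence is available to account for the difference between the two chlorine placements.

The compounds shown leave open whether a single chlorine could account for part or all of the lower number of compound 3. Also open, from the compounds shown here alone, is whether other groups on this phenyl ring, such as methoxy or trifluoromethyl, would give numbers as low as that of compound 3.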